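Nitro on the Benzimidazole Ring of Compound 1

The compounds below may be only part of what the source reports. "The series", "measured", "known", "first", "only" and "open" are said of these compounds alone.

Measured so far:
compound 1, `CCn1cc(-c2nc3ccccc3[nH]2)c(=O)c2cc(F)c(N3CCNCC3)nc21`, gives 4800 nM
compound 2, `CCn1cc(-c2nc3ccccc3o2)c(=O)c2cc(F)c(N3CCNCC3)nc21`, gives 15300 nM
compound 3, `CCn1cc(-c2nc3ccccc3s2)c(=O)c2cc(F)c(N3CCNCC3)nc21`, gives 2700 nM

The three compounds share one core and differ only in the azole attached to it. In a functional assay on A2780 cells (Homo sapiens) for cytotoxicity, read by MTT assay, with a stated time of 48 h (on this read-out higher numbers stand for weaker inhibition and lower numbers for stronger inhibition), compound 1 stands second highest of the three numbers. Its nearest neighbour is compound 3, with a 1.8-fold lower number from compound 1 to compound 3 (0.25 log units; within the scatter), so the two cannot be told apart. The furthest is compound 2, with a 3.2-fold higher number from compound 1 to compound 2 (0.50 log units; beyond the scatter). Between the other two, a 5.7-fold lower number from compound 2 to compound 3 (0.75 log units; beyond the scatter).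

Compound 4, `CCn1cc(-c2nc3ccc([N+](=O)[O-])cc3[nH]2)c(=O)c2cc(F)c(N3CCNCC3)nc21`, keeps the benzimidazole of compound 1 and adds a substituent to it: nitro in place of hydrogen on an aromatic carbon.

Among the measured compounds shown here, none of the measured steps bears directly on this change. For the measured compounds named here, every step so far exchanges the heteroatom of the azole; no measured pair adds a group to the fused carbon ring. There is therefore no measured basis for a step in either direction, and compound 4 is expected to stay within the scatter of compound 1, with no change at the digits printed from compound 1 to compound 4 (within the scatter). The estimate for compound 4 in this assay is 4800 nM, ranging from 1500 nM to 15000 nM.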

Compound 4, half-maximal inhibitory concentration: 12400 nM
Beside the measured number, compound 4's estimate is 2.6-fold (0.41 log units) below it; the measured number falls inside the stated range.
By their numbers in this assay, from the lowest: compounds 3 and 1 (each within the scatter of the next); then compounds 4 and 2 (each within the scatter of the next).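

In this assay, the six-membered aromatic ring of carbon only in the benzimidazole of compound 1 proves open to change: nitro in place of hydrogen on an aromatic carbon, meta to a fused ring and para to a fused ring, gives a 2.6-fold higher number from compound 1 to compound 4 (0.41 log units; beyond the scatter) and so a modest move towards weaker inhibition. Among the compounds shown here, the earlier compounds differed only in the heteroatom of the azole, and this is the first step showing that a group added to the carbon ring, with the azole left as it is, can also shift the number beyond the scatter. No supporting information bears on why the number moves in this direction.

Going by these compounds, a single substituent at a single place sets no trend, so it remains open whether an amine, a methoxy group or a chlorine atom on the same carbon would move the number the same way, less or not at all. On these data alone, it also remains open whether nitro on the same carbon would give a step of similar size on the benzothiazole of compound 3 or the benzoxazole of compound 2.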